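Chloro to Nitro Swap Tested at Two Ring Positions

This account rests on a few compounds, and the source may have more. Where it says the series, first, only, none or still open, it means among the compounds named here.

Measured compounds:
compound 1 `COc1cc(C(=O)c2cn(-c3ccc(Cl)cc3)cc2-c2ccccc2)cc(OC)c1OC`: 140 nM
compound 2 `COc1cc(C(=O)c2cn(-c3ccc([N+](=O)[O-])cc3)cc2-c2ccccc2)cc(OC)c1OC`: 4000 nM
compound 3 `COc1cc(C(=O)c2cn(-c3ccc(N)cc3)cc2-c2ccccc2Cl)cc(OC)c1OC`: 83 nM

These values come from a functional assay on MCF7 cells (Homo sapiens) for cytotoxicity, read by MTT assay, with a stated time of 96 h; a lower number here means a stronger inhibitor, a higher number a weaker inhibitor. Compound 1 and compound 2 differ by nitro in place of chloro on an aromatic carbon and this gave a 29-fold higher number from compound 1 to compound 2 (1.46 log units; beyond the scatter). The difference between the cores of compound 3 and compound 1 is not broken down here. Compound 4 `COc1cc(C(=O)c2cn(-c3ccc(N)cc3)cc2-c2ccccc2[N+](=O)[O-])cc(OC)c1OC` differs from compound 3 by nitro in place of chloro on an aromatic carbon. The two changes are the same kind of change but not the same: in compound 2 the nitro sits para to a large group, in compound 4 it sits ortho to a large group. Because a 29-fold higher number from compound 1 to compound 2 (1.46 log units; beyond the scatter) was large, compound 4 is expected to give a weaker number than compound 3, a step of about an 18-fold higher number from compound 3 to compound 4 (1.26 log units; beyond the scatter). The estimate for compound 4 is 1500 nM, between 400 nM and 6000 nM.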

Compound 4, half-maximal inhibitory concentration: 53 nM
For compound 4 the middle estimate is 28-fold (1.45 log units) above the measured one, outside the stated range (below it).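

In this assay, putting nitro in place of chloro on the 2-chlorophenyl group gives a 1.6-fold lower number from compound 3 to compound 4 (0.19 log units; within the scatter), so this pair shows no real difference. Set beside the earlier step, the same swap does not carry over from one core to the other: the same change on two cores in this assay, a 29-fold higher number (1.46 log units; beyond the scatter) from compound 1 to compound 2 and a 1.6-fold lower number (0.19 log units; within the scatter) from compound 3 to compound 4, 45-fold (1.65 log units) apart, beyond the scatter of two such steps. This shows that the size of the step on one core cannot predict the step on the other in this series, but not which difference between the two pairs is responsible, the place of the swapped group or the rest of the core.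

The compounds shown leave open how other groups, such as a nitrile or a trifluoromethyl, would behave in place of the chloro. Going by these compounds, it also remains open whether either result holds on a third core.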